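The source may report more compounds than this note shows. Statements on the series, on what has been measured and on what is new or still open speak of the compounds shown alone.

Measured so far in an assay on HEK293 cells for activation of Kir3.1/Kir3.2 (Homo sapiens), read by thallium flux; on this read-out lower numbers stand for smaller maximal responses and higher numbers for larger maximal responses: compound 1 `O=C(Cn1nnc(-c2ccccc2)n1)NC1CC2CCC1C2` gives 13%, and compound 2 `Cc1cc(NC(=O)Cn2nnc(-c3cccnc3)n2)n(C2CCCCC2)n1` gives 96%.

Compound 2 holds the highest of the two numbers; compound 1 stands far lower, a gap beyond the scatter. The two compounds differ in more than one place, so that gap is not tied to any single change and says nothing direct about the step that follows.

Compound 3 `Cc1cc(NC(=O)Cn2nnc(-c3ccc(Cl)c(Cl)c3)n2)n(C2CCCCC2)n1` differs from compound 2 in one place: 3,4-dichlorophenyl in place of pyridin-3-yl on an aromatic carbon. Among the compounds with values here, no measured pair shows this change, so nothing fixes its size. In this assay the estimate is a moderate lowering of the maximal response, beyond the scatter, though a result within the scatter of compound 2 is not ruled out. The expected step is a number 21 percentage points lower from compound 2 to compound 3 (beyond the scatter). For compound 3 the estimated value is 75%, in a range from 35% to 105%.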

Compound 3, largest response reached (Emax), in percent of the reference or control that the assay uses: 84%
Compound 3: middle estimate off by 9 percentage points, on the low side; the range from low to high includes it.
By their numbers in this assay, from the lowest: compound 1; then compound 3; then compound 2.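

Within the data shown here, on the aromatic carbon of the five-membered aromatic ring with 4 nitrogen, 3,4-dichlorophenyl in place of pyridin-3-yl gives a number 12 percentage points lower from compound 2 to compound 3 (beyond the scatter) in this assay as the first single-place step. The position thus accepts a ring of carbon only, with two chlorine atoms and no hydrogen-bond acceptor, and compound 3 at 84% still gives a large maximal response. No measurement at hand bears on the reason for this modest step.

This single step does not separate the loss of the ring nitrogen from the gain of the two chlorine atoms. The compounds shown also leave open how a plain phenyl ring, or a phenyl ring carrying an amine or a carboxylic acid, would stand at this position.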